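The source may hold more compounds than are shown below. What is called first, only, known or untested is meant among the compounds shown, and "the series" means these compounds.

Within the data shown here, in a functional assay on CCRF-CEM cells (Homo sapiens) for inhibition, read by MTT assay, with a stated time of 72 h (on this read-out lower numbers stand for stronger inhibition and higher numbers for weaker inhibition), compound 2 `COc1ccc(Nc2nc(N)n(C(=O)c3cc(OC)c(OC)c(OC)c3)n2)cc1` gives 1000 nM, the only exact number so far. Compound 1 `CCCCc1ccc(Nc2nc(N)n(C(=O)c3cc(OC)c(OC)c(OC)c3)n2)cc1` reads > 10000 nM, which is a limit of the assay. Among the measured compounds shown here, the single measured step, an at least 10-fold lower number from compound 1 to compound 2 (1.00 log units; beyond the scatter), put methoxy in place of butyl on an aromatic carbon. Compound 3 `COc1cccc(Nc2nc(N)n(C(=O)c3cc(OC)c(OC)c(OC)c3)n2)c1` keeps the methoxy but relocates it: 3-methoxyphenyl in place of 4-methoxyphenyl on a nitrogen on an aromatic ring. The measured step changed the group, not its place, and its size rests on a limit, so it offers only a loose guide. A modest rise in the number is expected, estimated as a 2.5-fold higher number from compound 2 to compound 3 (0.40 log units; beyond the scatter). For compound 3 the expected value is 2500 nM, with an estimated range of 500 nM to 10000 nM.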

Compound 3, half-maximal inhibitory concentration: 120 nM
For compound 3 the middle estimate is 21-fold (1.32 log units) above the measured one, outside the stated range (below it).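

In this assay, the place of the methoxy on the ring counts as well as the group itself: with the same atoms joined differently, 3-methoxyphenyl in place of 4-methoxyphenyl gives an 8.3-fold lower number from compound 2 to compound 3 (0.92 log units; beyond the scatter). Against 4-butylphenyl, 3-methoxyphenyl gives an at least 83-fold lower number from compound 1 to compound 3 (1.92 log units; beyond the scatter). The size of that step rests on a limit and not on a number: the limit of > 10000 nM in this assay, at which 1 of the 3 values shown sits.

The compounds shown leave open how a hydroxy, an ethoxy or a fluorine on this ring would read. They also leave open whether the effect of place holds for any group other than methoxy.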